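This account rests on a few compounds, and the source may have more. Where it says the series, first, only, none or still open, it means among the compounds named here.

The measured compounds in a functional assay on MDA-MB-231 cells (Homo sapiens) for inhibition, read by sulforhodamine B assay, with a stated time of 48 h; a higher number here means a weaker inhibitor of growth, a lower number a stronger inhibitor of growth:

Compound 1 `COc1ccc2c(c1)NC(=O)CN2c1nc(OCC2CC2)nc2ccccc12`: 45.2 nM
Compound 2 `COc1ccc2c(c1)NC(=O)CN2c1nc(NCc2ccncc2)nc2ccccc12`: 73.6 nM
Compound 3 `COc1ccc2c(c1)NC(=O)CN2c1nc(NC2CC2)nc2ccccc12`: 10.5 nM

Among these three numbers compound 1 stands second highest. Its nearest neighbour is compound 2, and the two values lie within the usual scatter (a 1.6-fold higher number from compound 1 to compound 2 (0.21 log units; within the scatter)); compound 3 lies furthest from it (a 4.3-fold lower number from compound 1 to compound 3 (0.63 log units; beyond the scatter)).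

Compound 4 `CCCCNc1nc(N2CC(=O)Nc3cc(OC)ccc32)c2ccccc2n1` has not yet been measured in this assay. It differs from compound 1 in one place: butylamino in place of cyclopropylmethoxy on an aromatic carbon.

Among the compounds with values here, two measured steps bear on this change. The step of a 4.3-fold lower number from compound 1 to compound 3 (0.63 log units; beyond the scatter) shows that a nitrogen-linked group in place of the oxygen-linked one gave a modestly lower number. The step of a 1.6-fold higher number from compound 1 to compound 2 (0.21 log units; within the scatter) shows that a nitrogen-linked group carrying a bulkier substituent gave a number within the scatter of compound 1. Compound 4 keeps the nitrogen link and carries a chain of the same size as the group it replaces, so a small to modest drop in the number, or none beyond the scatter, is expected.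

Compound 4 is therefore estimated at 25 nM, with a range from 8 nM to 80 nM. This estimate corresponds to an expected step of a 1.8-fold lower number from compound 1 to compound 4 (0.26 log units; within the scatter) in this assay.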

Compound 4, concentration for 50% growth inhibition: 7.19 nM
Estimate against measurement, compound 4: 3.5-fold (0.54 log units) above; the whole stated range lies above it.
By their numbers in this assay, from the lowest: compounds 4 and 3 (each within the scatter of the next); then compounds 1 and 2 (each within the scatter of the next).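

In this assay, placing butylamino instead of cyclopropylmethoxy on the carbon between two ring nitrogen atoms gives a 6.3-fold lower number from compound 1 to compound 4 (0.80 log units; beyond the scatter), so an open chain on nitrogen, with no ring, is well accepted at this position. Cyclopropyl and butyl on that nitrogen cannot be told apart, with a 1.5-fold lower number from compound 3 to compound 4 (0.16 log units; within the scatter), whereas replacing the pyridin-4-yl end of the (pyridin-4-yl)methyl group with propyl, which turns that group into butyl, gives a 10-fold lower number from compound 2 to compound 4 (1.01 log units; beyond the scatter). No measurement available here explains these differences.

The compounds shown leave open whether a butoxy group would match butylamino, which would separate the effect of the linking atom from that of the chain. They also leave open how a longer chain, such as hexylamino, or a dimethylamino group would fare at this position.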